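The source may hold more compounds than are shown below. What is called first, only, known or untested is meant among the compounds shown, and "the series" means these compounds.

Measured compounds:
- compound 1 `Cc1ccc(S(=O)(=O)n2cc(CN(Cc3cn(Cc4ccccc4)nn3)S(=O)(=O)c3ccccc3)c3ccccc32)cc1`: in a functional assay on 3T3-L1 cells (Mus musculus) for inhibition, with a stated time of 20 min, tested at 20 uM (on this read-out lower numbers stand for less inhibition and higher numbers for more inhibition at the one concentration tested (going by the name of the read-out)), compound 1 gives -18%
- compound 2 `Cc1ccc(S(=O)(=O)n2cc(CN(Cc3cccc(F)c3F)C(=O)C(F)(F)F)c3ccccc32)cc1`: in this assay compound 2 gives -5.5%
- compound 3 `COc1cc(OC)c(Cn2cc(CN(Cc3cn(S(=O)(=O)c4ccc(C)cc4)c4ccccc34)S(=O)(=O)c3ccc(C)cc3)nn2)c(OC)c1`: in this assay compound 3 gives -22%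

Among the measured compounds shown here, all three numbers lie below zero, so none of the measured compounds shows inhibition in this assay at the single concentration tested. Within that picture compound 2 stands highest of the three: its number lies above that of compound 1 by a gap beyond the usual scatter, and above that of compound 3 by a larger gap, also beyond the scatter. No pair of these compounds differs in just one place, so nothing can be said about what any single structural change does to the read-out.

Compound 4 `Cc1ccc(S(=O)(=O)n2cc(CNCc3cccc(F)c3F)c3ccccc32)cc1` is not yet measured. It differs from compound 2 in one place: hydrogen in place of (trifluoromethyl)carbonyl on an amine nitrogen. For the measured compounds named here, there is no measured step of this kind among the three compounds to lean on, and since all three read as no inhibition, the step from compound 2 to compound 4 is expected to stay within the scatter, as a number 2.5 percentage points higher from compound 2 to compound 4 (within the scatter) expresses. Compound 4 is therefore estimated at -3%, with a range from -22% to 16%.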

Compound 4, a percentage reported as inhibition, at one concentration (the size of the read-out at that concentration, not a potency): 46%
Beside the measured number, compound 4's estimate is 49 percentage points below it; the whole stated range lies below it.
By their numbers in this assay, from the lowest: compounds 3 and 1 (each within the scatter of the next); then compound 2; then compound 4.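

In this assay, among the compounds shown here, putting hydrogen in place of (trifluoromethyl)carbonyl on the amine nitrogen gives a number 51.5 percentage points higher from compound 2 to compound 4 (beyond the scatter), the first single-place change to be read. It shows that what sits on this nitrogen, with the rest of compound 4 the same as compound 2, can decide whether the read-out shows inhibition at all: the change takes away 6 heavy atoms, no ring among them, and turns a number below zero into a clearly positive one. The data give no measured reason why the loss of this group has so large an effect, so the step stands as an observation about this one pair.

The compounds shown leave open whether it is the free hydrogen on the nitrogen that matters or simply the absence of (trifluoromethyl)carbonyl, since a small group such as methyl or acetyl on the same amine nitrogen does not appear among them. For the compounds shown here, they also leave open whether the same change would have a similar effect on another compound, as this step rests on a single pair and no other pair in the set differs in this one place.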